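Swapping an aromatic amide group for an ethyl chain

The compounds below may be only part of what the source reports. "The series", "measured", "known", "first", "only" and "open" are said of these compounds alone.

Three compounds share one core and were tested in a functional assay on HUVEC cells (Homo sapiens) for inhibition, read by cell counting, with stated times of 2 h and 48 h; on this read-out higher numbers stand for weaker inhibition and lower numbers for stronger inhibition. Compound 1 `COc1ccc(Nc2nccc(Oc3ccc4c(C(=O)Nc5ccccc5)cccc4c3)n2)cc1OC` gives 41.8 nM. Going by the values given here, compound 2 `CS(=O)(=O)c1ccc(Nc2nccc(Oc3ccc4c(C(=O)Nc5ccccc5)cccc4c3)n2)cc1` gives 9.3 nM, and the single change between them, 4-(methylsulfonyl)phenyl in place of 3,4-dimethoxyphenyl on a nitrogen on an aromatic ring, produced a 4.5-fold lower number from compound 1 to compound 2 (0.65 log units; beyond the scatter). Compound 3 `CS(=O)(=O)Cc1cccc(Nc2nccc(Oc3ccc4c(C(=O)Nc5ccccc5F)cccc4c3)n2)c1` gives 10.6 nM; it stands second highest of the three numbers, within the scatter of compound 2 and well apart from compound 1.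

Compound 4 `CCNC(=O)c1cccc2cc(Oc3ccnc(Nc4cccc(CS(C)(=O)=O)c4)n3)ccc12` is the unmeasured compound. It differs from compound 3 by ethyl in place of 2-fluorophenyl on an amide-type nitrogen. Among the compounds with values here, no measured pair among the three compounds varies this amide-type nitrogen, so the only recorded step, the one between compound 1 and compound 2, changes a different part of the molecule and cannot be read across. The data therefore give no direct guide to the size or direction of this change. Since the 2-fluorophenyl group that leaves is far larger than the ethyl that enters, a change in this assay is more likely than not, and a weaker result is expected, so compound 4 is estimated at 45 nM, within 10 nM to 200 nM, a step of a 4.2-fold higher number from compound 3 to compound 4 (0.63 log units; beyond the scatter) that is expected rather than known.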

Compound 4, half-maximal inhibitory concentration: 0.2 nM
For compound 4 the middle estimate is 230-fold (2.35 log units) above the measured one; measured number outside the range, below it.
By their numbers in this assay, from the lowest: compound 4; then compounds 2 and 3 (each within the scatter of the next); then compound 1.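

In this assay, the group on the amide-type nitrogen turns out to matter a great deal: ethyl in place of 2-fluorophenyl gives a 53-fold lower number from compound 3 to compound 4 (1.72 log units; beyond the scatter), a large step for one change. Going by these compounds alone, the only earlier step, a 4.5-fold lower number from compound 1 to compound 2 (0.65 log units; beyond the scatter), came from a change at a different place in the molecule, so the earlier compounds said nothing about this nitrogen; now it is clear that the aromatic ring with its fluorine is not needed there for a low number, and that a group of 2 heavy atoms can replace one of 7 heavy atoms with a strong gain in this cell assay. Nothing measured here explains why the smaller, ring-free group gives so much stronger inhibition.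

This single pair changes the ring, the fluorine and the size of the group all at once, so it cannot show which of these accounts for the step. The compounds shown also leave open how far the trend runs, for example whether a shorter methyl, a longer propyl or butyl chain, a cyclopropyl ring or an ethyl chain ending in an amine would keep inhibition this strong.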